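Replacing the 4-methoxyphenyl group with thiophen-2-yl

The compounds below may be only part of what the source reports. "The series", "measured", "known", "first", "only" and "open" are said of these compounds alone.

In a functional assay on A549 cells (Homo sapiens) for inhibition, read by MTT assay, with a stated time of 48 h (on this read-out higher numbers stand for weaker inhibition and lower numbers for stronger inhibition), compound 1 (`CCc1ccc(-c2nc3ccccn3c2Sc2ccccc2)cc1`) gives 56200 nM and compound 2 (`COc1ccc(-c2nc3ccccn3c2Sc2ccccc2)cc1`) gives 58400 nM, so compound 2 stands level with compound 1 within the scatter. Compound 3 (`c1ccc(Sc2c(-c3cccs3)nc3ccccn23)cc1`) has thiophen-2-yl in place of 4-methoxyphenyl on an aromatic carbon. For the measured compounds named here, the only measured step, a 1.0-fold higher number from compound 1 to compound 2 (0.02 log units; within the scatter), exchanges ethyl for methoxy and leaves the aromatic ring in place, so it bears on this change only loosely. No step beyond the scatter is expected in this assay, and the data give no direction. The expected step is a 1.2-fold lower number from compound 2 to compound 3 (0.07 log units; within the scatter). Compound 3 is estimated at 50000 nM, with a range of 20000 nM to 120000 nM.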

Compound 3, half-maximal inhibitory concentration: 16900 nM
The estimate for compound 3 lay 3.0-fold (0.47 log units) above the measured number; the measured number lies below the stated range.
By their numbers in this assay, from the lowest: compound 3; then compounds 1 and 2 (each within the scatter of the next).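

In this assay this position on the shared core proves responsive: exchanging ethyl for methoxy moved nothing beyond the scatter, whereas thiophen-2-yl gives a 3.5-fold lower number from compound 2 to compound 3 (0.54 log units; beyond the scatter) and a 3.3-fold lower number from compound 1 to compound 3 (0.52 log units; beyond the scatter). Both steps are modest and run the same way from 4-methoxyphenyl and from 4-ethylphenyl. Nothing available accounts for this shift. Going by these compounds, whether it follows the sulfur atom or the five-membered aromatic ring stays open. Furan-2-yl, thiophen-3-yl or unsubstituted phenyl at this position would separate these readings.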